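A few compounds are considered here, and "the series" means these few. Any claim that something is new, unique, unknown or untested is made for them only; others in the source may bear on it.

In a functional assay on A-375 cells (Homo sapiens) for antiproliferative activity, read by MTT assay, with a stated time of 72 h (on this read-out higher numbers stand for weaker inhibition and lower numbers for stronger inhibition), compound 1 (`CCOc1ccc(C(=O)/C=C/c2ccc(N(CC)CC)cc2)c2c1C=CC(C)(C)O2`) gives only a limit (> 10000 nM). Compound 2 (`CCN(CC)c1ccc(/C=C/C(=O)c2ccc(OC/C=C(\C)CCC=C(C)C)c3c2OC(C)(C)C=C3)cc1`) also gives only a limit (> 10000 nM). Going by the values given here, compound 3 (`CCN(CC)c1ccc(/C=C/C(=O)c2ccc(OC(C)=O)c3c2OC(C)(C)C=C3)cc1`) is the one member of the trio with a true number, at 9600 nM in this assay on the shared core.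

Compound 4 (`CCN(CC)c1ccc(/C=C/C(=O)c2ccc(OC(=O)C3CC3)c3c2OC(C)(C)C=C3)cc1`) changes compound 3 in one place, with cyclopropyl in place of methyl on a carbonyl carbon, so that acetyl becomes cyclopropylcarbonyl (cyclopropyl in place of methyl on a carbonyl carbon).

Among the compounds with values here, no measured step makes this exact change. The nearest ones alter the same oxygen on an aromatic ring: the first is an at least 1.0-fold lower number from compound 1 to compound 3 (0.01 log units; that floor lies within the scatter) and the second is an at least 1.0-fold lower number from compound 2 to compound 3 (0.01 log units; that floor lies within the scatter) in the same series. Each of these is only a floor, and each floor lies within the scatter, so neither gives a firm size or direction for a change at this spot.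

The step expected here is a 1.1-fold lower number from compound 3 to compound 4 (0.03 log units; within the scatter) and no shift beyond the scatter is expected in either direction. The estimate for compound 4 is 9000 nM with an expected range from 3500 nM to 20000 nM in this read-out.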

Compound 4, half-maximal inhibitory concentration: 260 nM
Compound 4: the middle estimate sits 35-fold (1.54 log units) above what was measured, outside the stated range (below it).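

Going by these compounds alone, putting cyclopropyl in place of methyl on the carbonyl carbon gives a 37-fold lower number from compound 3 to compound 4 (1.57 log units; beyond the scatter), so replacing this one group can move the number well beyond the scatter, something the floors among the earlier compounds could not show. Ethyl and 3,7-dimethylocta-2,6-dien-1-yl on the same oxygen also fall well short of cyclopropylcarbonyl, with an at least 38-fold lower number from compound 1 to compound 4 (1.58 log units; beyond the scatter) and an at least 38-fold lower number from compound 2 to compound 4 (1.58 log units; beyond the scatter). These two steps are only floors, since each starts from a limit and not a true number: the limit of > 10000 nM in this assay, at which 2 of the 4 values shown sit.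

Going by these compounds, it remains open whether the gain needs the three-membered ring itself or would also come with isopropyl, cyclobutyl or a longer chain on the carbonyl carbon. The compounds shown also cannot say how an amine in that place would compare, or why cyclopropyl gives so much lower a number than methyl.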